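The compounds below may be only part of what the source reports. "The series", "measured", "known", "first", "only" and "open" are said of these compounds alone.

Measured compounds in a functional assay on K562 cells (Homo sapiens) for antiproliferative activity, with a stated time of 72 h; a higher number here means a weaker inhibitor, a lower number a stronger inhibitor:
compound 1, `OC[C@H]1O[C@@H](n2cnc3c(NCc4cccc(F)c4)ncnc32)[C@H](O)[C@@H]1O`: 7600 nM
compound 2, `COc1cccc(CNc2ncnc3c2ncn3[C@@H]2O[C@H](CO)[C@@H](O)[C@H]2O)c1OC`: limit only, > 166000 nM
compound 3, `OC[C@H]1O[C@@H](n2cnc3c(NCc4cc(F)cc(F)c4)ncnc32)C(O)C1O`: limit only, > 166000 nM

Compound 2 is known in this assay only as a limit, > 166000 nM, with no number behind it. It therefore sits at the weak end of what has been measured, together with compound 3, which is also reported only as a limit, > 166000 nM; both share (the limit of > 166000 nM in this assay, at which 2 of the 3 values shown sit). Among the measured compounds shown here, compound 1 is the one compound with a number, 7600 nM.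

Compound 4, `Cc1cccc(CNc2ncnc3c2ncn3[C@@H]2O[C@H](CO)[C@@H](O)[C@H]2O)c1O`, is the next member to be measured in this assay. It differs from compound 2 as follows: 2-hydroxy-3-methylphenyl in place of 2,3-dimethoxyphenyl on a saturated chain carbon bound to a nitrogen on an aromatic ring.

One measured step changes the aryl group at the same place: an at least 21-fold higher number from compound 1 to compound 2 (1.33 log units; beyond the scatter). It shows that the aryl group at this position can move the number from a measurable value to the limit, but it gives no direct guide for the 2-hydroxy-3-methylphenyl group, and compound 3 shows that another small aryl group also reaches the limit.

The expectation for compound 4 is a return toward a measurable number, an at least 2.7-fold lower number from compound 2 to compound 4 (0.44 log units; beyond the scatter), stated with low confidence. Compound 4 is estimated at 60000 nM, range 10000 nM to 166000 nM, with a real chance that only a limit is reported again.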

Compound 4, half-maximal inhibitory concentration: 18000 nM
For compound 4 the middle estimate is 3.3-fold (0.52 log units) above the measured one; the range from low to high includes it.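

In this assay, 2-hydroxy-3-methylphenyl in place of 2,3-dimethoxyphenyl on the saturated chain carbon gives an at least 9.2-fold lower number from compound 2 to compound 4 (0.96 log units; beyond the scatter), so a change confined to the aryl group can bring a compound back from the limit to a measured number. The 3-fluorophenyl group still holds a modest edge, with a 2.4-fold higher number from compound 1 to compound 4 (0.37 log units; beyond the scatter), which means that an aryl group carrying two substituents can stay within reach of the monofluorinated one, although compound 2 and compound 3, which also carry two substituents, go against any general rule. The true size of the step from the dimethoxy compound remains unknown because compound 2 is reported only as a limit: the limit of > 166000 nM in this assay, at which 2 of the 4 values shown sit.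

The change to compound 4 swaps both substituents at once, so the separate contributions of the hydroxyl and the methyl remain unresolved, and 2-hydroxyphenyl or 3-methylphenyl alone would be needed to divide them. Going by these compounds, how an amine or a carboxylic acid on the aryl ring, or a longer chain in place of the single saturated chain carbon, would read in this assay also remains open.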